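The compounds below may be only part of what the source reports. "The series", "measured", "known", "first", "only" and "open" are said of these compounds alone.

Measured compounds:
- compound 1, `C/C(=N\O)c1ccc(NC(=O)Cn2nc(-c3ccc(Cl)cc3)nc2N)cc1`: 7.43%
- compound 2, `COc1cc(-c2nc(N)n(CC(=O)Nc3ccc(/C(C)=N\O)cc3)n2)cc(OC)c1OC`: 4.21%
- compound 3, `c1ccc(-c2nc3sc(-c4ccccc4)cn3n2)cc1`: 16%

The read-out throughout is a functional assay on NCI-H23 cells (Homo sapiens) for inhibition, read by sulforhodamine B assay, with a stated time of 48 h, tested at 10 uM; on this read-out higher numbers stand for more inhibition of growth at the one concentration tested and lower numbers for less inhibition of growth. Compound 1 and compound 2 share an amide-linked oxime motif; compound 1 gives 7.43% and compound 2 gives 4.21%, both low numbers. Compound 3, built on a different core, gives 16%, the highest of the three numbers; its gap to compound 1 lies within the scatter, while its gap to compound 2 lies beyond it, so only against compound 2 can compound 3 be said to inhibit growth more.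

Compound 4, `COc1ccc(-c2nc3sc(-c4ccccc4)cn3n2)cc1`, has not yet been measured. Its difference from compound 3 is methoxy in place of hydrogen on an aromatic carbon. Going by the values given here, no two measured compounds differ in one place, so there is no measured step to lean on. A single methoxy on the core of compound 3 is expected to change the number little, and the step of a number 1 percentage points lower from compound 3 to compound 4 (within the scatter) is estimated to stay within the scatter. Compound 4 is therefore expected to give about 15%, in a range from 3% to 30%.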

Compound 4, percent growth inhibition at one concentration: 28%
The estimate for compound 4 lay 13 percentage points below the measured number; the range from low to high includes it.
By their numbers in this assay, from the lowest: compounds 2, 1 and 3 (each within the scatter of the next, the first and the last beyond it); then compound 4.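

In this assay, going by these compounds alone, methoxy in place of hydrogen on an aromatic carbon, para to a large group, gives a number 12 percentage points higher from compound 3 to compound 4 (beyond the scatter), which is the first change in a single place that can be read. Within the data shown here, the earlier compounds offered no such pair, so this step is the first sign that the number responds to a substituent at this position of the six-membered aromatic ring. Nothing available explains why this change raises the number.

A single pair cannot show whether the rise is particular to methoxy or would also come with a hydroxyl, a fluorine, an amine or a longer ethoxy group at the same place. It also leaves open whether methoxy would have a similar effect on another aromatic carbon of compound 3.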